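Cutting an Octyl Chain Down to Butyl

The source may hold more compounds than are shown below. What is called first, only, known or untested is meant among the compounds shown, and "the series" means these compounds.

Compound 1, `CCCCCCCCc1cn([C@H]2C[C@@H]3OP(=O)(O)OC[C@H]3O2)c(=O)[nH]c1=O`, carries an octyl chain on its core. For the measured compounds named here, in a functional assay on L1210 cells (Mus musculus) (on this read-out higher numbers stand for weaker inhibition and lower numbers for stronger inhibition), compound 1 gives 193 ug/mL, the lowest of the two numbers measured so far. Compound 2, `CCCCCc1cn([C@H]2C[C@H](O)[C@@H](CO)O2)c(=O)[nH]c1=O`, carries a pentyl chain on a different sugar and gives 477 ug/mL in this assay. Compound 3, `CCCc1cn([C@H]2C[C@H](O)[C@@H](CO)O2)c(=O)[nH]c1=O`, gives > 500 ug/mL in this assay, which is a limit of the assay rather than a number. The step of an at least 1.0-fold higher number from compound 2 to compound 3 (0.02 log units; that floor lies within the scatter) cannot be sized further because compound 3 sits at the limit of > 500 ug/mL in this assay, at which 1 of the 3 values shown sits.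

Compound 4, `CCCCc1cn([C@H]2C[C@@H]3OP(=O)(O)OC[C@H]3O2)c(=O)[nH]c1=O`, keeps the core of compound 1 but shortens its chain: hydrogen in place of butyl on a saturated chain carbon, four bonds along the chain from an aromatic carbon. The one measured shortening, from pentyl to propyl, points, if anywhere, toward a higher number, and compound 2 with its shorter chain already sits higher than compound 1. A move to a higher number is therefore expected for compound 4, roughly a 2.1-fold higher number from compound 1 to compound 4 (0.32 log units; beyond the scatter). Compound 4 is estimated to give 400 ug/mL in this assay, within a range from 200 ug/mL to 800 ug/mL.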

Compound 4, concentration for 50% inhibition: 33.5 ug/mL
Compound 4: middle estimate off by 12-fold (1.08 log units), on the high side, and the stated range ends above it.
By their numbers in this assay, from the lowest: compound 4; then compound 1; then compound 2. At a limit, above all of these: compound 3.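

On the core of compound 1, removing part of the chain does not weaken inhibition in this assay; it strengthens it, with a 5.8-fold lower number from compound 1 to compound 4 (0.76 log units; beyond the scatter) as octyl gives way to butyl. For the compounds shown here, this is the first step here with a number at both ends, and it shows that, for this pair, the longer chain goes with weaker inhibition. The earlier pair on the other sugar could not show a direction: compound 3 gives > 500 ug/mL in this assay, and that value is a limit, not a number.

Nothing shown explains why butyl gives the lower number. Still open, as far as these compounds go, is how a propyl chain, a hexyl chain or a chain carrying an amine would behave in this place on the same core, and whether the same shortening would lower the number on the sugar of compound 2.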